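This account rests on a few compounds, and the source may have more. Where it says the series, first, only, none or still open, it means among the compounds named here.

Going by the values given here, in a functional assay on ECa-109 cells (Homo sapiens) for inhibition, read by MTT assay, with a stated time of 72 h (a lower number here means a stronger inhibitor, a higher number a weaker inhibitor), compound 2 `Cc1ccc(Cn2cc(CSC(=S)N3CCN(C(=O)OC(C)(C)C)CC3)nn2)cc1` gives 47900 nM, the only actual number among the two values shown. Compound 1 `COc1ccc(-n2cc(CSC(=S)N3CCN(C(=O)OC(C)(C)C)CC3)nn2)cc1` gives in this assay only a limit, > 128000 nM. Among the compounds with values here, the single measured step, an at least 2.6-fold lower number from compound 1 to compound 2 (0.42 log units; beyond the scatter), is the sole guide available.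

Compound 3 `Cc1ccc(-n2cc(CSC(=S)N3CCN(C(=O)OC(C)(C)C)CC3)nn2)cc1` differs from compound 2 by 4-methylphenyl in place of 4-methylbenzyl on an aromatic nitrogen. This change runs in the opposite sense to the measured step, which also replaced a group on the aromatic nitrogen with a 4-methylbenzyl and brought the number down. Reversing the benzyl back to a directly bonded methylphenyl is therefore expected to push the number up, by roughly a 2.3-fold higher number from compound 2 to compound 3 (0.36 log units; beyond the scatter), with a real chance that the assay again returns only a limit, as with the limit of > 128000 nM in this assay, at which 1 of the 2 values shown sits. Compound 3 is accordingly estimated at 110000 nM, within a range of 40000 nM to 300000 nM.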

Compound 3, half-maximal inhibitory concentration: 114000 nM
Compound 3: middle estimate off by 1.0-fold (0.02 log units), on the low side; measured number inside the range.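

In this assay, with the methyl kept in both groups, 4-methylphenyl in place of 4-methylbenzyl on the aromatic nitrogen gives a 2.4-fold higher number from compound 2 to compound 3 (0.38 log units; beyond the scatter). This pair therefore compares the benzyl and phenyl attachments on their own, which the earlier step could not do, as it also exchanged the methoxy for a methyl. The other new step, an at least 1.1-fold lower number from compound 1 to compound 3 (0.05 log units; that floor lies within the scatter), does not separate methyl from methoxy on the aromatic carbon, and compound 1 stands only as a limit, so that comparison has a floor but no measured size: the limit of > 128000 nM in this assay, at which 1 of the 3 values shown sits.

The compounds shown leave open how an amine or a carboxylic acid on the benzene ring would read in this assay. They also leave open whether a 4-methylphenethyl group, with its longer chain, on the aromatic nitrogen would continue the direction seen with 4-methylbenzyl.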